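The source may report more compounds than this note shows. Statements on the series, on what has been measured and on what is new or still open speak of the compounds shown alone.

In an assay on isolated protein for inhibition of coagulation factor X (Oryctolagus cuniculus), tested at 1 uM (on this read-out higher numbers stand for more inhibition at the one concentration tested (going by the name of the read-out) and lower numbers for less inhibition), compound 3 `O=C1[C@@H](NS(=O)(=O)c2cc3c(Cl)nccc3s2)CCN1CCNc1ccncc1` gives 39%, the second highest of three numbers: compound 1 `O=C1[C@@H](NS(=O)(=O)c2ccc(-c3ccon3)s2)CCN1Cc1cc2c[nH]ccc-2n1` gives 17% and compound 2 `O=C1[C@@H](NS(=O)(=O)c2cc3ncccc3s2)CCN1Cc1cc2c[nH]ccc-2n1` gives 61%. For the measured compounds named here, the single measured step, a number 44 percentage points higher from compound 1 to compound 2 (beyond the scatter), concerns a replacement on a sulfonyl sulfur. Compound 4 `O=C1[C@@H](NS(=O)(=O)c2cc3c(Cl)nccc3s2)CCN1Cc1cc2c[nH]ccc-2n1` differs from compound 3 elsewhere: a group of 9 heavy atoms (7 carbon, 2 nitrogen; one five-membered aromatic ring with 1 hetero atom, one six-membered aromatic ring with 1 hetero atom) in place of a group of 8 heavy atoms (6 carbon, 2 nitrogen; one six-membered aromatic ring with 1 hetero atom), on a saturated chain carbon bound to an amide-type nitrogen in a ring. Going by the values given here, no measured step covers this change; the group that enters is, however, the one carried by compound 1 and compound 2, whose numbers lie on either side of the value of compound 3. The expectation is therefore a moderate rise with wide uncertainty. Compound 4 is expected to give 55%, in a range from 30% to 80%. This estimate corresponds to an expected step of a number 16 percentage points higher from compound 3 to compound 4 (beyond the scatter).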

Compound 4, a percentage reported as inhibition, at one concentration (the size of the read-out at that concentration, not a potency): 35%
Estimate against measurement, compound 4: 20 percentage points above; the measured number falls inside the stated range.
By their numbers in this assay, from the lowest: compound 1; then compounds 4 and 3 (each within the scatter of the next); then compound 2.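

In this assay, the swap on the saturated chain carbon bound to an amide-type nitrogen in a ring gives a number 4 percentage points lower from compound 3 to compound 4 (within the scatter) and so does not separate the two groups when the sulfonyl sulfur carries the chlorine-bearing group. With that side held fixed, changes on the sulfonyl sulfur give a number 26 percentage points lower from compound 2 to compound 4 (beyond the scatter) and a number 18 percentage points higher from compound 1 to compound 4 (beyond the scatter) as steps beyond the scatter. No evidence bears on why these steps differ in size. From the compounds shown here alone, whether the two groups also match with the sulfonyl group of compound 2 stays open, as does the effect of a methoxy group or an amine in place of the chlorine.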